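This account rests on a few compounds, and the source may have more. Where it says the series, first, only, none or still open, it means among the compounds named here.

Compound 1 `CC(C)N1CCN(Cc2csc(N)c2C(=O)c2ccc(Cl)cc2)CC1`, compound 2 `Nc1scc(CN2CCN(c3ccc(F)c(F)c3)CC2)c1C(=O)c1ccc(Cl)cc1` and compound 3 `Nc1scc(CN2CCN(c3cccc(Cl)c3)CC2)c1C(=O)c1ccc(Cl)cc1` were measured in an assay on CHO cells for displacement of a labelled ligand from adenosine receptor A3 (Homo sapiens), read by scintillation counting, with a stated time of 120 min, tested at 10 uM; on this read-out lower numbers stand for less inhibition and higher numbers for more inhibition at the one concentration tested (going by the name of the read-out).
Compound 1 gives 0%.
Compound 2 gives 1%.
Compound 3 gives 1%.

In this assay compound 3 stands level with compound 2 at the digits reported, the two of them making up the upper pair of the three numbers; its nearest neighbour is compound 2, with no change at the digits printed from compound 2 to compound 3 (within the scatter), and its furthest is compound 1, with a number 1 percentage points higher from compound 1 to compound 3 (within the scatter). All three numbers lie within the scatter of one another, so none of the three can be set apart from the others.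

Compound 4 `Nc1scc(CN2CCN(c3ccccc3Cl)CC2)c1C(=O)c1ccc(Cl)cc1` is not yet measured. It differs from compound 3 in one place: 2-chlorophenyl in place of 3-chlorophenyl on an amine nitrogen in a ring. Going by the values given here, the steps that bear on this change are the ones that alter the group on the same ring nitrogen. Replacing isopropyl by an aryl group gave a number 1 percentage points higher from compound 1 to compound 2 (within the scatter) and a number 1 percentage points higher from compound 1 to compound 3 (within the scatter), and exchanging one aryl group for another gave no change at the digits printed from compound 2 to compound 3 (within the scatter). Every one of these lies within the scatter, and moving the chlorine around the same ring is a change of the same kind. The expected step is therefore none beyond the scatter, no change at the digits printed from compound 3 to compound 4 (within the scatter). Compound 4 is expected to give 1% in this assay, with a range from -8% to 10%.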

Compound 4, a percentage reported as inhibition, at one concentration (the size of the read-out at that concentration, not a potency): 0%
Compound 4: the middle estimate sits 1 percentage points above what was measured; the range from low to high includes it.
By their numbers in this assay, from the lowest: compounds 1, 4, 2 and 3 (each within the scatter of the next).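

In this assay, 2-chlorophenyl in place of 3-chlorophenyl on an amine nitrogen in a ring gives a number 1 percentage points lower from compound 3 to compound 4 (within the scatter), so moving the chlorine around this ring, with the atoms themselves unchanged, does not set the two compounds apart. The same group gives a number 1 percentage points lower from compound 2 to compound 4 (within the scatter) and no change at the digits printed from compound 1 to compound 4 (within the scatter), which extends the earlier picture: 2-chlorophenyl, 3-chlorophenyl, 3,4-difluorophenyl and isopropyl on this ring nitrogen all give numbers that cannot be told apart at the one concentration tested. Nothing available explains why these numbers stay together.

The compounds shown leave open whether a different kind of group on this ring nitrogen, such as a benzyl group, a pyridine ring, a carboxylic acid or a longer chain, would give a number beyond the scatter. They also leave open whether a change elsewhere on the shared core, such as replacing the chlorine of the aryl ketone with a methoxy group or replacing the free amine with an amide, would separate any compound from this set.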